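This account rests on a few compounds, and the source may have more. Where it says the series, first, only, none or still open, it means among the compounds named here.

Measured so far:
Compound 1 `O=C1NCc2c(NCc3ccccc3[N+](=O)[O-])cccc21` gives 8% in an assay for inhibition of Indoleamine 2,3-dioxygenase 1 (Homo sapiens), with stated times of 10 min and 60 min, tested at 10 uM; on this read-out lower numbers stand for a weaker effect and higher numbers for a stronger effect at the one concentration tested.
Compound 2 `FC(F)(F)c1cc(NC[C@H]2CCCN2)c2cn[nH]c2c1` gives 34% in this assay.
Compound 3 `CS(=O)(=O)c1ccc(CNc2cc(C(F)(F)F)cc3[nH]ncc23)c([N+](=O)O)c1` gives 63% in this assay.

Compound 2 stands second highest of the three numbers in this assay. Its nearest neighbour is compound 1, whose number lies lower by a gap beyond the scatter; its furthest is compound 3, whose number lies higher, again beyond the scatter. Within the data shown here, no two of the measured compounds differ in only one place, so no single step between them can be read off; the numbers show only that compound 3, which carries an arylmethyl group on a nitrogen attached to the same shared core as compound 2, gives the highest value.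

Compound 4 `FC(F)(F)c1cc(NCc2cccc(Br)c2)c2cn[nH]c2c1` is not yet measured. It differs from compound 2 in one place: 3-bromophenyl in place of pyrrolidin-2-yl on a saturated chain carbon bound to a nitrogen on an aromatic ring. Compound 2 and compound 3 both carry a substituent on the chain carbon bound to the aromatic nitrogen, and compound 3 with its aromatic substituent gives 63%, so an aromatic substituent at this place is compatible with a higher number. A modest upward step from compound 2 to compound 4 is therefore expected, of size a number 11 percentage points higher from compound 2 to compound 4 (beyond the scatter), close to the edge of the scatter. Compound 4 is expected to give about 45% in this assay, within a range from 15% to 75%.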

Compound 4, a percentage reported as inhibition, at one concentration (the size of the read-out at that concentration, not a potency): 23%
Compound 4: the middle estimate sits 22 percentage points above what was measured, and the stated range covers the measured number.
By their numbers in this assay, from the lowest: compound 1; then compound 4; then compound 2; then compound 3.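

Among these compounds, the step of a number 11 percentage points lower from compound 2 to compound 4 (beyond the scatter) in this assay gives the first direct reading at this place, on a saturated chain carbon bound to a nitrogen on an aromatic ring, with the rest of the shared core held the same. It shows that, in this pair, replacing pyrrolidin-2-yl with 3-bromophenyl moves the number down, so a six-membered aromatic ring of carbon only does not by itself bring a higher number here. The exchange alters several things at once, removing the ring nitrogen, the hydrogen-bond donor and acceptor counted on pyrrolidin-2-yl and the defined stereocentre while adding bromine, and no measurement at hand accounts for the step.

Which of these alterations carries the step remains open, as does whether the bromine on the ring helps or hurts. An unsubstituted phenyl, a 3-chlorophenyl, a piperidin-2-yl or an open-chain primary amine at the same place would each separate part of the exchange, and the other stereoisomer of the pyrrolidin-2-yl group would isolate the defined stereocentre.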